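Swapping Methoxy for Ethyl on the Nitroaryl Ring

A few compounds are considered here, and "the series" means these few. Any claim that something is new, unique, unknown or untested is made for them only; others in the source may bear on it.

Compound 1 `COc1ccc([N+](=O)[O-])cc1S(=O)(=O)N(C)/N=C/c1cnn2ccc(C#N)cc12` is the anchor of this small set. For the measured compounds named here, in a functional assay on NZB5 cells (Homo sapiens) for inhibition, read by thymidine incorporation, with a stated time of 5 days (on this read-out higher numbers stand for weaker inhibition and lower numbers for stronger inhibition), compound 1 gives 90 nM, and that is the only actual number among the three measured entries. Compound 2 `Cc1ccccc1S(=O)(=O)N(C)/N=C/c1cnn2ccc(C#N)cc12` carries a methyl instead of the methoxy and has no nitro group. For compound 2 the assay reports only a limit, > 20000 nM, which is the limit of > 20000 nM in this assay, at which 1 of the 3 values shown sits. Compound 3 `Cc1ccc([N+](=O)[O-])cc1S(=O)(=O)N(Cc1ccccc1)/N=C/c1cnn2ccc(C#N)cc12` also carries a methyl and has a benzyl in place of the methyl on the nitrogen; for compound 3 this assay reports "not determined" (no result reported), that is, no result. Going by the values given here, no two measured compounds differ in a single place, so no measured step can be read from the data; compound 1 and compound 2 simply show one number and one limit.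

Compound 4 `CCc1ccc([N+](=O)[O-])cc1S(=O)(=O)N(C)/N=C/c1cnn2ccc(C#N)cc12` is the compound still to be tested. Compared with compound 1 it carries ethyl in place of methoxy on an aromatic carbon. Ethyl keeps the heavy-atom count of methoxy but drops its hydrogen-bond acceptor, while the nitro group and everything else stay as in compound 1. The expected step of a 2.8-fold higher number from compound 1 to compound 4 (0.44 log units; beyond the scatter) is a modest weakening, only slightly beyond the scatter. Compound 4 is therefore expected to give about 250 nM, within a range from 60 nM to 1500 nM.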

Compound 4, half-maximal inhibitory concentration: 170 nM
Compound 4: middle estimate off by 1.5-fold (0.17 log units), on the high side, and the stated range covers the measured number.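

In this assay, ethyl in place of methoxy on this aromatic carbon, ortho to a large group and para to a nitro group, gives a 1.9-fold higher number from compound 1 to compound 4 (0.28 log units; within the scatter), so the two compounds cannot be told apart on this read-out. For the compounds shown here, this pair is the first direct comparison at this position, and it shows that a value in this range does not depend on the methoxy oxygen: ethyl has no hydrogen-bond acceptor, yet the result stays within the scatter of that of compound 1. The data shown offer no measurement that explains why this swap leaves the result within the scatter.

As far as these compounds go, whether this position would accept other groups, such as an amine, a carboxylic acid or a longer chain like butyl, remains open, as one swap between two groups of equal heavy-atom count says little about the range of groups tolerated. From the compounds shown here alone, the part played by the nitro group is also open: compound 1 and compound 2 differ in more than one place, and compound 2 gives > 20000 nM, which is a limit of the assay and not a number.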